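Methyl to methoxy on the oxetane: working notes

The source may hold more compounds than are shown below. What is called first, only, known or untested is meant among the compounds shown, and "the series" means these compounds.

Compound 1 `CC1(CS(C)(=O)=O)CN(c2cc(COc3ccc(F)c(F)c3F)nc(-c3ccccn3)n2)C1`: 6310 nM in a functional assay on cells for antagonist activity at Free fatty acid receptor 1 (Homo sapiens), read by TR-FRET and inositol phosphate accumulation, with a stated time of 2 h; on this read-out higher numbers stand for weaker inhibition and lower numbers for stronger inhibition
Compound 2 `Fc1ccc(OCc2cc(OCC3CCC3)nc(-c3ccccn3)n2)c(F)c1F`: 12.6 nM
Compound 3 `CC1(COc2cc(COc3ccc(F)c(F)c3F)nc(-c3ccccn3)n2)COC1`: 79.4 nM

Compound 3 stands second highest of the three numbers in this assay: its nearest neighbour is compound 2, a 6.3-fold higher number from compound 2 to compound 3 (0.80 log units; beyond the scatter), and its furthest is compound 1, a 79-fold lower number from compound 1 to compound 3 (1.90 log units; beyond the scatter). Compound 4 `COC1(COc2cc(COc3ccc(F)c(F)c3F)nc(-c3ccccn3)n2)COC1` differs from compound 3 by methoxy in place of methyl on a saturated ring carbon. Within the data shown here, no measured step makes exactly this change. Among the measured compounds shown here, the only step that touches the same ring is a 6.3-fold higher number from compound 2 to compound 3 (0.80 log units; beyond the scatter), which also puts an oxygen into this ring and was modest; the steps of a 500-fold lower number from compound 1 to compound 2 (2.70 log units; beyond the scatter) and a 79-fold lower number from compound 1 to compound 3 (1.90 log units; beyond the scatter) swap the whole side chain and say little here. A further single oxygen on the same ring is therefore expected to give a small step in this assay, if any, with a higher number the more likely direction. Compound 4 is estimated at 125 nM, range 40 nM to 400 nM, an expected step of a 1.6-fold higher number from compound 3 to compound 4 (0.20 log units; within the scatter) that stays close to the scatter.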

Compound 4, half-maximal inhibitory concentration: 501 nM
Compound 4: middle estimate off by 4.0-fold (0.60 log units), on the low side; measured number above the stated range.
By their numbers in this assay, from the lowest: compound 2; then compound 3; then compound 4; then compound 1.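

On the saturated ring carbon, methoxy in place of methyl is no small change in this assay (a 6.3-fold higher number from compound 3 to compound 4 (0.80 log units; beyond the scatter)), and it is as large as the step that put the oxygen into the ring (a 6.3-fold higher number from compound 2 to compound 3 (0.80 log units; beyond the scatter)). Against cyclobutyl the 3-methoxyoxetan-3-yl group loses far more (a 40-fold higher number from compound 2 to compound 4 (1.60 log units; beyond the scatter)), yet the (3-methoxyoxetan-3-yl)methoxy side chain still keeps a lower number than the azetidinyl side chain of compound 1 (a 13-fold lower number from compound 1 to compound 4 (1.10 log units; beyond the scatter)). Nothing at hand explains the rise.

Still open, on these data alone, is whether the added oxygen or the added carbon drives the step. A hydroxyl, an ethoxy or an amine on the same ring carbon could separate the two.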